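Chlorophenyl to fluorophenyl: following the step from compound 1

This account rests on a few compounds, and the source may have more. Where it says the series, first, only, none or still open, it means among the compounds named here.

Measured compounds in a functional assay on MCF7 cells (Homo sapiens) for antiproliferative activity, read by MTT assay, with a stated time of 72 h; on this read-out lower numbers stand for stronger inhibition and higher numbers for weaker inhibition:
compound 1 `COc1cc(-n2cnc3ccc(-c4ccccc4Cl)cc32)cc(OC)c1OC` — > 10000 nM
compound 2 `COc1cc(-n2cnc3ccc(-c4ccc(C)cc4F)cc32)cc(OC)c1OC` — 56 nM
compound 3 `COc1cc(-n2cnc3ccc(-c4ccc([N+](=O)[O-])cc4)cc32)cc(OC)c1OC` — 740 nM

Compound 1 stands at the edge of what this assay reports: its value is a limit, not a number, as shown by the limit of > 10000 nM in this assay, at which 1 of the 3 values shown sits. Compound 4 `COc1cc(-n2cnc3ccc(-c4ccc(F)cc4)cc32)cc(OC)c1OC` is not yet measured. It differs from compound 1 by 4-fluorophenyl in place of 2-chlorophenyl on an aromatic carbon.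

Two measured steps leave the same starting point. The step of an at least 170-fold lower number from compound 1 to compound 2 (2.25 log units; beyond the scatter) shows a large fall in the number, and the step of an at least 13-fold lower number from compound 1 to compound 3 (1.13 log units; beyond the scatter) shows another, smaller but still beyond the scatter. Both replace the 2-chlorophenyl group, and in both cases the number drops well below the limit at which compound 1 sits. The change to compound 4 is of the same kind, a different substituted phenyl in place of 2-chlorophenyl, so a large step downward in this assay is expected for compound 4 as well. Which of the two measured steps it will resemble cannot be read from the data; a size between them is taken.

Compound 4 is therefore expected to give about 250 nM, within 50 nM to 2500 nM, meaning an expected step of an at least 40-fold lower number from compound 1 to compound 4 (1.60 log units; beyond the scatter).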

Compound 4, half-maximal inhibitory concentration: 1770 nM
Compound 4: middle estimate off by 7.1-fold (0.85 log units), on the low side; the range from low to high includes it.
By their numbers in this assay, from the lowest: compound 2; then compound 3; then compound 4. At a limit, above all of these: compound 1.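

In this assay, a ring carrying a single fluoro group as 4-fluorophenyl still gives a step clear of the 2-chlorophenyl compound, though a much smaller one than the earlier replacements, an at least 5.6-fold lower number from compound 1 to compound 4 (0.75 log units; beyond the scatter), and this step is only a bound because compound 1 carries a limit and not a number: the limit of > 10000 nM in this assay, at which 1 of the 4 values shown sits. On the 4-substituted phenyl, the exchange of nitro for fluoro moves the number only modestly, a 2.4-fold higher number from compound 3 to compound 4 (0.38 log units; beyond the scatter), so a simple substituted phenyl at this position does not by itself reach the level of the best compound shown. For the compounds shown here, the large step of a 32-fold higher number from compound 2 to compound 4 (1.50 log units; beyond the scatter) places most of the strength of the series so far in the 2-fluoro-4-methylphenyl group as a whole, not in the presence of a fluoro group alone.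

Whether the methyl or the fluoro of that group carries the gain remains open, as 4-methylphenyl and 2-fluorophenyl are not among the compounds shown. Also open, as far as these compounds go, is how an amine or a carboxylic acid on this phenyl would behave, and whether the weak result of compound 1 belongs to the chloro group itself or to its place, which 4-chlorophenyl would settle.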